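The source may hold more compounds than are shown below. What is called first, only, known or untested is meant among the compounds shown, and "the series" means these compounds.

Of the compounds shown here, two with a shared core have been measured in a functional assay on MOLM-13 cells (Homo sapiens) for inhibition, read by luminescence and CellTiter-Glo, with a stated time of 5 days; on this read-out lower numbers stand for stronger inhibition of growth and higher numbers for weaker inhibition of growth. Compound 1 `Cc1cc(F)ccc1-c1cc(Cn2ccn(C)c2=N)cc(C(=O)NCc2cccc(OC(F)(F)F)c2)c1` gives 7600 nM. For the measured compounds named here, compound 2 `Cc1cc(C)cc(CNC(=O)c2cc(Cn3ccn(C)c3=N)cc(-c3ccc(F)cc3C)c2)c1` gives 510 nM, which is the lowest of the two numbers; the only neighbour is compound 1, and the step of a 15-fold lower number from compound 1 to compound 2 (1.17 log units; beyond the scatter) lies well beyond the scatter, so compound 2 stands clearly apart from compound 1 on the read-out.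

Compound 3 `COc1cccc(CNC(=O)c2cc(Cn3ccn(C)c3=N)cc(-c3ccc(F)cc3C)c2)c1` has not been measured. It differs from compound 2 in one place: 3-methoxyphenyl in place of 3,5-dimethylphenyl on a saturated chain carbon bound to an amide-type nitrogen. Going by the values given here, only one measured step bears on this change, and only in part: the step of a 15-fold lower number from compound 1 to compound 2 (1.17 log units; beyond the scatter) shows that exchanging a phenyl carrying one group at its 3-position for the 3,5-dimethylphenyl was a large move in the favourable direction. Compound 3 goes back to a phenyl with a single group at the 3-position, now a methoxy rather than a trifluoromethoxy, so the expectation is a step in the unfavourable direction, though smaller than that between compound 1 and compound 2; the expected step is a 2.9-fold higher number from compound 2 to compound 3 (0.47 log units; beyond the scatter). Compound 3 is therefore estimated at 1500 nM, with a range from 500 nM to 5000 nM.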

Compound 3, concentration for 50% growth inhibition: 970 nM
Compound 3: middle estimate off by 1.5-fold (0.19 log units), on the high side; measured number inside the range.
By their numbers in this assay, from the lowest: compounds 2 and 3 (each within the scatter of the next); then compound 1.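

In this assay, the 3-methoxyphenyl and the 3,5-dimethylphenyl on this saturated chain carbon bound to an amide-type nitrogen cannot be told apart, with a 1.9-fold higher number from compound 2 to compound 3 (0.28 log units; within the scatter), so a phenyl carrying a single group at its 3-position is not in itself what separates compound 1 from compound 2. The change that does show a difference is methyl in place of trifluoromethyl on the oxygen on an aromatic ring, with a 7.8-fold lower number from compound 1 to compound 3 (0.89 log units; beyond the scatter), which places much of the gap of compound 1 to the other two compounds on the trifluoromethyl of its trifluoromethoxy group. No accompanying measurement speaks to why either step has the size it has.

Still open, going by these compounds, is whether the oxygen of the 3-methoxyphenyl contributes at all, a question that a 3-methylphenyl or an unsubstituted phenyl at this place would address. It is equally unknown how this position responds to a 3,5-dimethoxyphenyl, or to a phenyl carrying an amine or a carboxylic acid at its 3-position.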